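Adding a second hydroxy ring substituent to a coumarin-type ligand

The source may hold more compounds than are shown below. What is called first, only, known or untested is meant among the compounds shown, and "the series" means these compounds.

Of the compounds shown here, three sharing one core have been tested. Compound 1 `CCOc1cccc2cc(-c3ccc([N+](=O)[O-])cc3)c(=O)oc12` is measured in an assay on CHO cells for displacement of a labelled ligand from adenosine receptor A1 (Homo sapiens), read by radioligand binding (a lower number here means a stronger inhibitor, a higher number a weaker inhibitor), as > 100000 nM, which is a limit of the assay and not a number. Compound 2 `O=c1oc2c(O)cccc2cc1-c1ccccc1` gives 4620 nM in this assay. Compound 3 `O=c1oc2c(O)c(O)ccc2cc1-c1ccccc1` gives 2400 nM, the lowest of the two numbers recorded, though the step of a 1.9-fold lower number from compound 2 to compound 3 (0.28 log units; within the scatter) shows that it sits within the scatter of compound 2. The step from compound 3 to compound 4 `O=c1oc2c(O)c(O)ccc2cc1-c1ccc(O)cc1` is a change (hydroxy in place of hydrogen on an aromatic carbon), placed on the six-membered aromatic ring of carbon only, para to a large group. For the measured compounds named here, the one measured step of the same kind, a 1.9-fold lower number from compound 2 to compound 3 (0.28 log units; within the scatter), added a hydroxy on the shared core and moved the number by less than the scatter. A similar change is therefore expected from adding a hydroxy at a different place: an estimated step of a 1.3-fold lower number from compound 3 to compound 4 (0.12 log units; within the scatter). Compound 4 is expected to give about 1800 nM in this assay, between 600 nM and 5500 nM.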

Compound 4, inhibition constant: 12500 nM
Compound 4: middle estimate off by 6.9-fold (0.84 log units), on the low side; measured number above the stated range.
By their numbers in this assay, from the lowest: compounds 3 and 2 (each within the scatter of the next); then compound 4. At a limit, above all of these: compound 1.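

The same change does not act alike at every place on these compounds. On the six-membered aromatic ring of carbon only, para to a large group, the added hydroxy gives a 5.2-fold higher number from compound 3 to compound 4 (0.72 log units; beyond the scatter), so compound 4 is a weaker inhibitor than compound 3 in this assay, whereas the earlier hydroxy on the shared core gave only a 1.9-fold lower number from compound 2 to compound 3 (0.28 log units; within the scatter). Nothing in the data at hand accounts for this difference between the two places.

From the compounds shown here alone, it remains open whether this weakening is specific to the hydroxy or would also appear with another group at this place, such as a methoxy, an amine or a fluorine. Going by these compounds, it is also open whether the same hydroxy would have a similar effect on compound 2, which carries one hydroxy fewer on the shared core.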